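The source may report more compounds than this note shows. Statements on the series, on what has been measured and on what is new or still open speak of the compounds shown alone.

Of the compounds shown here, three so far have numbers in an assay on isolated protein for inhibition of ubiquitin carboxyl-terminal hydrolase 7 (Homo sapiens), read by fluorescence, with stated times of 30 min and 1 h; a higher number here means a weaker inhibitor, a lower number a stronger inhibitor. Compound 1 `Cc1cc(Cl)cc(-c2ccnc3cc(CN4C(=O)C5CC5C4=O)sc23)c1C[C@@H]1CNC[C@@H](C)O1` gives 0.39 nM in this assay, and compound 3 `Cc1cc(Cl)cc(-c2ccnc3cc(CN4C(=O)CCC4=O)sc23)c1CN1[C@@H](C)CNC[C@@H]1C` gives 0.32 nM. Compound 2 `O=C([C@H]1Cc2cc(Cl)cc(-c3ccnc4cc(C(O)(CO)CCl)sc34)c2O1)N1CCNCC1` gives 9 nM, the highest of the three, and its gaps to compound 1 and to compound 3 both lie beyond the usual scatter, so compound 2 is the weakest inhibitor of the set. The step considered here leads from compound 2 to compound 4 `O=C([C@H]1Cc2cc(Cl)cc(-c3ccnc4ccsc34)c2O1)N1CCNCC1`, where (hydrogen in place of 1-(chloromethyl)-1,2-dihydroxyethyl on an aromatic carbon). Among the compounds with values here, no measured pair shows this kind of change, so there is nothing to calibrate against. Removing the whole group is expected to give a weaker inhibitor, a step of a 6.7-fold higher number from compound 2 to compound 4 (0.82 log units; beyond the scatter). Compound 4 is therefore estimated at 60 nM, with a range from 15 nM to 300 nM.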

Compound 4, half-maximal inhibitory concentration: 90 nM
Estimate against measurement, compound 4: 1.5-fold (0.18 log units) below, and the stated range covers the measured number.
By their numbers in this assay, from the lowest: compounds 3 and 1 (each within the scatter of the next); then compound 2; then compound 4.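

In this assay, replacing the 1-(chloromethyl)-1,2-dihydroxyethyl group with hydrogen on the aromatic carbon next to the ring sulfur gives a 10-fold higher number from compound 2 to compound 4 (1.00 log units; beyond the scatter), so what sits at this position matters for inhibition. Even so, compound 4 still gives 90 nM, so measurable inhibition does not depend on this group. Going by these compounds, the chloromethyl and hydroxyl parts leave together, so it remains open which part matters and how a simple hydroxymethyl or aminomethyl group would compare here. Nothing given here accounts for the size of this step.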